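This account rests on a few compounds, and the source may have more. Where it says the series, first, only, none or still open, it means among the compounds named here.

Working notes on the series in a functional assay on the whole organism (Tail, strain ICR) with Mus musculus as the target, in the tail flick test, with a stated time of 90 min, at a dose of 25 umol/kg by the oral route; on this read-out higher numbers stand for a stronger effect at the one dose given and lower numbers for a weaker effect.

The shared core carries a side chain that ends in a free carboxylic acid in the three measured compounds. Compound 1 `C[C@H](NC(=O)CN(c1nc(Cl)nc2[nH]cnc12)C1CC1)C(=O)O` gives 43.5% in this assay and stands highest of the three numbers. Compound 2 `NC(=O)CC[C@H](NC(=O)CN(c1nc(Cl)nc2[nH]cnc12)C1CC1)C(=O)O` gives 41.1%; the step of a number 2.4 percentage points lower from compound 1 to compound 2 (within the scatter) is within the scatter, so no order between compound 1 and compound 2 can be read. Compound 3 `CSCC[C@H](NC(=O)CN(c1nc(Cl)nc2[nH]cnc12)C1CC1)C(=O)O` gives 14%; the steps of a number 29.5 percentage points lower from compound 1 to compound 3 (beyond the scatter) and a number 27.1 percentage points lower from compound 2 to compound 3 (beyond the scatter) are both beyond the scatter and modest in size.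

Compound 4 `C[C@H](NC(=O)CN(c1nc(Cl)nc2[nH]cnc12)C1CC1)C(=O)OCc1ccccc1` is still to be measured in this assay. Against compound 1 it differs by benzyl in place of hydrogen on an oxygen next to a carbonyl group. All three measured steps concern the saturated chain carbon and leave the carboxylic acid untouched; none of them bears on a change at the oxygen next to the carbonyl group, so the measured steps give no direct guide to the size or direction of the step to compound 4. The expectation therefore rests on the value of compound 1 alone, with a wide range around it.

For compound 4 an estimate of 40% is made, within 15% to 65%, which means an expected step of a number 3.5 percentage points lower from compound 1 to compound 4 (within the scatter).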

Compound 4, a percentage reported as activity, at one dose (the size of the read-out at that dose, not a potency): 44.2%
Estimate against measurement, compound 4: 4.2 percentage points below, and the stated range covers the measured number.
By their numbers in this assay, from the lowest: compound 3; then compounds 2, 1 and 4 (each within the scatter of the next).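

For the compounds shown here, the first change at the oxygen next to a carbonyl group, benzyl in place of hydrogen, gives a number 0.7 percentage points higher from compound 1 to compound 4 (within the scatter) in this assay. Carboxy to benzyloxycarbonyl therefore leaves no readable difference at this single oral dose and time, and a free carboxylic acid at this position is not needed for compound 4 to give a number of this size. Unlike the changes on the saturated chain carbon, where the step to compound 3 lies beyond the scatter, this change brings in an aromatic ring and removes the acid without a readable step, though no measurement shown here accounts for this outcome.

Going by these compounds, it remains open whether a smaller group at the same oxygen, such as methyl or ethyl, or a primary amide in place of the carboxylic acid, would also leave the number within the scatter of compound 1. On these data alone, it also remains open whether benzyl at this oxygen would give a similarly small step on the chains of compound 2 and compound 3, and whether the parity between compound 1 and compound 4 would hold at other doses or times.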